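Swapping a thiazole for a pyrazole on the shared core

The source may report more compounds than this note shows. Statements on the series, on what has been measured and on what is new or still open speak of the compounds shown alone.

Compound 1 `CCCS(=O)(=O)Nc1cccc2c1CCC2c1ncc[nH]1`: 1340 nM
Compound 2 `CS(=O)(=O)Nc1cccc2c1CCC2c1ncc[nH]1`: 70 nM
Compound 3 `c1cc(-c2nccs2)c2c(c1)C(c1ncc[nH]1)CC2`: 426 nM

In a functional assay on CHO cells for agonist activity at Alpha-1A adrenergic receptor (Homo sapiens), read by FLIPR and calcium flux (a higher number here means that more compound is needed for the effect, a lower number that less compound is needed), compound 3 stands second highest of the three, with compound 1 giving a 3.1-fold lower number from compound 1 to compound 3 (0.50 log units; beyond the scatter) and compound 2 giving a 6.1-fold higher number from compound 2 to compound 3 (0.78 log units; beyond the scatter). Compound 4 `c1cc(-c2cn[nH]c2)c2c(c1)C(c1ncc[nH]1)CC2` differs from compound 3 by 1H-pyrazol-4-yl in place of 1,3-thiazol-2-yl on an aromatic carbon. For the measured compounds named here, no measured step swaps one five-membered ring for another at this position; the two steps that touch it, a 3.1-fold lower number from compound 1 to compound 3 (0.50 log units; beyond the scatter) and a 6.1-fold higher number from compound 2 to compound 3 (0.78 log units; beyond the scatter), were modest in size, so a modest step in this assay is expected here, in either direction. Compound 4 is estimated at 300 nM, within 100 nM to 900 nM, a step of a 1.4-fold lower number from compound 3 to compound 4 (0.15 log units; within the scatter).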

Compound 4, half-maximal effective concentration: 14 nM
The estimate for compound 4 lay 21-fold (1.33 log units) above the measured number; measured number outside the range, below it.
By their numbers in this assay, from the lowest: compound 4; then compound 2; then compound 3; then compound 1.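

In this assay, this aromatic carbon separates two five-membered aromatic rings with the same heavy-atom count, giving a 30-fold lower number from compound 3 to compound 4 (1.48 log units; beyond the scatter) when 1H-pyrazol-4-yl replaces 1,3-thiazol-2-yl. The earlier compounds shown here showed no such swap, and they did not show that a ring here could give a lower number than either sulfonyl-bearing group: a 5.0-fold lower number from compound 2 to compound 4 (0.70 log units; beyond the scatter) for methanesulfonamido and a 96-fold lower number from compound 1 to compound 4 (1.98 log units; beyond the scatter) for (propylsulfonyl)amino. Nothing measured here explains the gap. The compounds shown leave open whether the hydrogen-bond donor of 1H-pyrazol-4-yl matters, and how an amine or a carboxylic acid would fare on this carbon.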